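The source may hold more compounds than are shown below. What is called first, only, known or untested is meant among the compounds shown, and "the series" means these compounds.

Measured in a functional assay on K562 cells (Homo sapiens) for cytotoxicity, read by MTT assay, with a stated time of 5 days; a higher number here means a weaker inhibitor, a lower number a stronger inhibitor:

- compound 1 `COc1ccc(-c2cnnn2-c2cc(OC)c(OC)c(OC)c2)cc1N` gives 11 nM here
- compound 2 `COc1ccc(Cn2nncc2-c2cc(OC)c(OC)c(OC)c2)cc1N` gives 730 nM here
- compound 3 `COc1ccc(-c2cnnn2Cc2cc(OC)c(OC)c(OC)c2)cc1` gives 5560 nM here

Compound 3 is the weakest inhibitor of the three in this assay, and it sits beyond the usual scatter of both others. Compound 2 is its nearest neighbour, and compound 1 lies much further off, at the strong end of the series.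

The next compound is compound 4 `COc1ccc(-c2cnnn2Cc2cc(OC)c(OC)c(OC)c2)cc1Br`, which is still unmeasured. It differs from compound 3 at one place: bromo in place of hydrogen on an aromatic carbon. The change turns 4-methoxyphenyl into 3-bromo-4-methoxyphenyl, with the bromo ortho to a methoxy group and meta to a large group.

Going by the values given here, no measured pair shows this change alone, and the three values give only a loose guide to its size. Compound 3 reads 5560 nM in this series, the highest number of the three, so a move toward a lower number seems more likely than a move upward. The expected change is modest, an estimated 2.2-fold lower number from compound 3 to compound 4 (0.35 log units; beyond the scatter) in the direction of a stronger inhibitor, and it may not clear the scatter by much. Compound 4 is estimated at 2500 nM as a middle value, with an expected range from 600 nM to 9000 nM for the measurement.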

Compound 4, half-maximal inhibitory concentration: > 10000 nM
Compound 4 was reported as a limit; the forecaster's own chance of this, stated with the estimate: 10%; middle value at least 4.0-fold (0.60 log units) from the limit.
By their numbers in this assay, from the lowest: compound 1; then compound 2; then compound 3. At a limit, above all of these: compound 4.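

In this assay compound 4 gives > 10000 nM, which is a limit of the assay and not a number. The step for bromo in place of hydrogen on an aromatic carbon reads an at least 1.7-fold higher number from compound 3 to compound 4 (0.25 log units; that floor lies within the scatter), so this change, ortho to a methoxy group and meta to a large group, gives no sign of a stronger inhibitor, although the printed floor alone does not establish a real loss. This is the first single-place change in the series that can be read at all, and its true size stays unknown because the reading stops at a limit: the limit of > 10000 nM in this assay, at which 1 of the 4 values shown sits.

What the compounds shown leave open is how the core of compound 3 would read in this assay with a smaller halogen such as fluoro, or with an amine, at this same position. They also leave open whether bromo in place of hydrogen would give a similar result on the core of compound 1, where the rings are joined directly rather than through a carbon link.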